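The source may hold more compounds than are shown below. What is called first, only, known or untested is meant among the compounds shown, and "the series" means these compounds.

Measured so far:
compound 1 `COc1ccccc1Sc1c[nH]c2ccc(Cl)cc12` — 17500 nM
compound 2 `Clc1ccc2[nH]cc(Sc3ccccc3)c2c1` — > 200000 nM

In an assay on isolated protein for inhibition of Indoleamine 2,3-dioxygenase 1 (Homo sapiens), read by HPLC, with a stated time of 60 min, in the presence of a further agent that is not named here (a higher number here means a weaker inhibitor, a lower number a stronger inhibitor), compound 2 returns only a limit, (the limit of > 200000 nM in this assay, at which 1 of the 2 values shown sits), so no number is known for it. Compound 3 `COc1ccc(Sc2c[nH]c3ccc(Cl)cc23)cc1` differs by methoxy in place of hydrogen on an aromatic carbon. Within the data shown here, the one measured step that touches a methoxy, an at least 11-fold higher number from compound 1 to compound 2 (1.05 log units; beyond the scatter), is large, but it concerns a methoxy at a different position and runs into the limit, so its size is itself only a bound. Adding a methoxy is therefore expected to lower the number, probably by a fair margin, yet with wide uncertainty. The step expected is an at least 3.3-fold lower number from compound 2 to compound 3 (0.52 log units; beyond the scatter). Compound 3 is estimated at 60000 nM, within 10000 nM to 300000 nM.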

Compound 3, half-maximal inhibitory concentration: 16000 nM
Estimate against measurement, compound 3: 3.8-fold (0.57 log units) above; low and high end bracket the measured number.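

In this assay, a methoxy para to a large group also carries a large step (an at least 12-fold lower number from compound 2 to compound 3 (1.09 log units; beyond the scatter)), so the gain is not tied to the methoxy position of compound 1. Compound 1 gives 17500 nM and compound 3 gives 16000 nM and these values do not separate the two placements. The step is only a bound because compound 2 stands at a limit: the limit of > 200000 nM in this assay, at which 1 of the 3 values shown sits.

Open, as far as these compounds go, is whether another group at this place, such as an amine, a carboxylic acid or a longer chain, keeps this gain.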